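Amide substituent change in a bile acid receptor agonist series

This account rests on a few compounds, and the source may have more. Where it says the series, first, only, none or still open, it means among the compounds named here.

Measured compounds:
compound 1 `CC(C)OC(=O)C1CN(C(=O)c2cccc(Cl)c2)CC(C)(C)c2cc(C#N)[nH]c21` gives 103% in an assay on HEK293 cells for agonist activity at Bile acid receptor (Homo sapiens), read by a luciferase reporter; a lower number here means a smaller maximal response, a higher number a larger maximal response
compound 2 `CC(C)OC(=O)C1=CN(C(=O)c2ccc(F)cc2)CC(C)(C)c2cc(C#N)[nH]c21` gives 119% in this assay
compound 3 `CC(C)OC(=O)C1=CN(C(=O)C2CCCCC2)CC(C)(C)c2cc(C#N)[nH]c21` gives 124% in this assay

Compound 1 stands lowest of the three numbers in this assay; the value of compound 2 sits above it beyond the scatter, and the value of compound 3 sits further above it, also beyond the scatter. Among the compounds with values here, no single-point step connects compound 1 to either of the other two, so only the values themselves are compared here.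

Compound 4 `CC(C)OC(=O)C1CN(C(=O)C2CCOCC2)CC(C)(C)c2cc(C#N)[nH]c21` keeps the core of compound 1 and differs only at the amide: oxan-4-yl in place of 3-chlorophenyl on a carbonyl carbon

Within the data shown here, the one measured step that bears on this is the exchange of an aromatic six-membered ring for a saturated six-membered ring on the same carbonyl carbon, a number 5 percentage points higher from compound 2 to compound 3 (within the scatter). That step was within the scatter. The change from compound 1 to compound 4 is of the same kind, a saturated ring replacing an aromatic one, though here the ring carries an oxygen and the aromatic ring that leaves carries chlorine, a combination not covered by any measured pair.

For compound 4 a step of a number 5 percentage points higher from compound 1 to compound 4 (within the scatter) is expected, at most a small rise. Compound 4 is therefore estimated at 108%, with a range from 90% to 128%.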

Compound 4, largest response reached (reported as efficacy), in percent of the reference or control that the assay uses: 112%
The estimate for compound 4 lay 4 percentage points below the measured number, within the range that was stated.
By their numbers in this assay, from the lowest: compounds 1, 4, 2 and 3 (each within the scatter of the next, the first and the last beyond it).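

In this assay, oxan-4-yl in place of 3-chlorophenyl on a carbonyl carbon gives a number 9 percentage points higher from compound 1 to compound 4 (within the scatter), so on the core of compound 1 this position accepts a non-aromatic ring carrying a ring oxygen and losing the chlorine, with no step beyond the scatter. Read with a number 5 percentage points higher from compound 2 to compound 3 (within the scatter) in the same assay, this assay, this makes two exchanges of an aromatic six-membered ring for a non-aromatic one on this carbonyl carbon, on two different cores, and neither step lies beyond the scatter, with no compound shown going against this. Nothing measured here accounts for this outcome or separates the part played by the ring oxygen from that of the lost chlorine.

The compounds shown leave open whether a piperidin-4-yl ring, with a ring nitrogen in place of the oxygen, or an open butyl chain on the same carbonyl carbon would also stay within the scatter of compound 1. Also open, from the compounds shown here alone, is whether oxan-4-yl behaves the same way on the core of compound 2, since only the maximal response is available for this series.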